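A few compounds are considered here, and "the series" means these few. Any claim that something is new, unique, unknown or untested is made for them only; others in the source may bear on it.

Of the compounds shown here, three sharing one core have been tested in a functional assay on DLD-1 cells (Homo sapiens) for inhibition, read by MTT assay, with a stated time of 72 h; a higher number here means a weaker inhibitor, a lower number a stronger inhibitor. Compound 1 `COc1ccc(CNCc2c(OC)cc(Oc3cccc(Nc4ccccc4)c3)cc2OC)cc1` gives 1910 nM in this assay. Compound 2 `COc1cc(Oc2cccc(Nc3ccccc3)c2)cc(OC)c1CNCc1ccc(Cl)cc1` gives 3740 nM, and the change between them, chloro in place of methoxy on an aromatic carbon, amounts to a 2.0-fold higher number from compound 1 to compound 2 (0.29 log units; within the scatter). Compound 3 `COc1cc(Oc2cccc(Nc3ccccc3)c2)cc(OC)c1CNC(C)C` reaches only the limit of this assay, > 20000 nM. Compound 1 thus gives the lowest of the two plain numbers, though the gap to compound 2 lies within the scatter, so the two cannot be told apart.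

Compound 4 `COc1cc(Oc2cccc(Nc3ccccc3)c2)cc(OC)c1CCO` has not yet been measured. It differs from compound 1 in one place: hydroxymethyl in place of (4-methoxybenzyl)amino on a saturated chain carbon bound to an aromatic carbon. The closest guide is the step in which the 4-methoxybenzyl group on the amine nitrogen was traded for isopropyl, an at least 10-fold higher number from compound 1 to compound 3 (1.01 log units; beyond the scatter), alongside the matching step an at least 5.3-fold higher number from compound 2 to compound 3 (0.72 log units; beyond the scatter). Both show that giving up the benzyl group costs a great deal, and compound 4 goes further, giving up the amine as well. A loss at least as large is therefore expected, toward weaker inhibition, and a limit rather than a number is a real possibility because of the limit of > 20000 nM in this assay, at which 1 of the 3 values shown sits. The expected step is a 16-fold higher number from compound 1 to compound 4 (1.20 log units; beyond the scatter). Compound 4 is estimated at 30000 nM, between 8000 nM and 100000 nM.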

Compound 4, half-maximal inhibitory concentration: 18100 nM
For compound 4 the middle estimate is 1.7-fold (0.22 log units) above the measured one; measured number inside the range.
By their numbers in this assay, from the lowest: compounds 1 and 2 (each within the scatter of the next); then compound 4. At a limit, above all of these: compound 3.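

In this assay, among these compounds, the earlier steps changed only the group on the amine nitrogen, whereas here the whole (4-methoxybenzyl)amino group, aromatic ring and nitrogen together, gives way to hydroxymethyl, and the step is a 9.5-fold higher number from compound 1 to compound 4 (0.98 log units; beyond the scatter). The same exchange starting from the (4-chlorobenzyl)amino group gives a 4.8-fold higher number from compound 2 to compound 4 (0.68 log units; beyond the scatter), so both benzylamines lose clearly, yet the shared core carrying only a 2-hydroxyethyl chain still returns a plain number. The exchange of isopropylamino for hydroxymethyl gives an at least 1.1-fold lower number from compound 3 to compound 4 (0.04 log units; that floor lies within the scatter), so these two groups cannot be ranked, because compound 3 stands at a limit and not at a number: the limit of > 20000 nM in this assay, at which 1 of the 4 values shown sits.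

The compounds shown leave open whether the loss follows the amine nitrogen or the aromatic ring, since the two depart together in this change. A benzyl ether, with oxygen in place of the amine nitrogen, would keep the ring without the nitrogen, and a primary amine would keep the nitrogen without the ring, so the pair could pull the two apart.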